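Swapping the Oxazolyl for tert-Butyl on the Amide Nitrogen

The source may report more compounds than this note shows. Statements on the series, on what has been measured and on what is new or still open speak of the compounds shown alone.

Among the measured compounds shown here, compound 1 `Cc1ccc(OCC(=O)N(Cc2cccs2)c2ncco2)cc1` holds the lowest of the two numbers so far in an assay on HEK293 cells for agonist activity at transient receptor potential cation channel subfamily M member 8 (Homo sapiens), read by fluorescence and calcium flux, with a stated time of 15 min (on this read-out higher numbers stand for an effect only at larger amounts of compound and lower numbers for an effect already at smaller amounts), where compound 1 gives 0.3 nM. The other measured compound, compound 2 `CCN(Cc1cccs1)C(=O)COc1ccccc1`, gives 1400 nM in this assay, far beyond the scatter from compound 1. Compound 3 `Cc1ccc(OCC(=O)N(Cc2cccs2)C(C)(C)C)cc1` awaits measurement; it differs from compound 1 by tert-butyl in place of 1,3-oxazol-2-yl on an amide-type nitrogen. For the measured compounds named here, no measured pair isolates this exchange. The account expects the step of a 330-fold higher number from compound 1 to compound 3 (2.52 log units; beyond the scatter), a rise well beyond the scatter. Compound 3 is therefore estimated at 100 nM, within a range from 5 nM to 2000 nM.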

Compound 3, half-maximal effective concentration: 11000 nM
For compound 3 the middle estimate is 110-fold (2.04 log units) below the measured one, and the stated range ends below it.
By their numbers in this assay, from the lowest: compound 1; then compound 2; then compound 3.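

In this assay, among the compounds shown here, the exchange on the amide-type nitrogen gives a 37000-fold higher number from compound 1 to compound 3 (4.56 log units; beyond the scatter) and is the first single change at this position, showing that the read-out here depends strongly on which group this nitrogen carries. The ring-bearing 1,3-oxazol-2-yl, with its hydrogen-bond acceptors, cannot be replaced by tert-butyl, which has neither, without a large loss. No available evidence explains the size of this step.

The compounds shown leave open whether the ring or its hetero atoms matter. A phenyl or a 1,3-thiazol-2-yl on this nitrogen would help separate the two.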